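The compounds below may be only part of what the source reports. "The series", "measured", "known", "first", "only" and "open" are said of these compounds alone.

Of the compounds shown here, three have so far been measured in an assay on RBL-1 cells for inhibition of Polyunsaturated fatty acid 5-lipoxygenase (Rattus norvegicus); a lower number here means a stronger inhibitor, a higher number a weaker inhibitor. Compound 1 `CSc1cccc(N2CCNC(=O)N2)c1` gives 14000 nM. Compound 3 `O=C1NCCN(c2ccccn2)N1` gives 26000 nM, a number that lies within the usual scatter of the result for compound 1, so the two cannot be told apart. Compound 2 `CCCCC1CN(c2ccccc2)NC(=O)N1` gives 1500 nM, a lower number than compound 1 by more than the scatter, which makes compound 2 the stronger inhibitor of that pair and leaves compound 1 among the weaker results seen. The next compound, compound 4 `O=C1NCCN(c2cccc(-c3nccs3)c2)N1`, differs from compound 1 in a single place: 1,3-thiazol-2-yl in place of methylsulfanyl on an aromatic carbon. Among the measured compounds shown here, no measured pair shows this exact change, so its effect is unknown; the step from compound 1 to compound 4 is expected to be modest, toward a lower number, as a 2.8-fold lower number from compound 1 to compound 4 (0.45 log units; beyond the scatter). Compound 4 is therefore estimated at 5000 nM, within a range from 1000 nM to 25000 nM.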

Compound 4, half-maximal inhibitory concentration: 35000 nM
Beside the measured number, compound 4's estimate is 7.0-fold (0.85 log units) below it, and the stated range ends below it.
By their numbers in this assay, from the lowest: compound 2; then compounds 1, 3 and 4 (each within the scatter of the next, the first and the last beyond it).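

Putting 1,3-thiazol-2-yl in place of methylsulfanyl on this aromatic carbon gives a 2.5-fold higher number from compound 1 to compound 4 (0.40 log units; beyond the scatter) in this assay, so compound 4 is the weaker inhibitor of the pair. This is the only pair shown that differs in one place, and it gives the only direct reading of a change at this position. Nothing available explains why the larger group gives the higher number.

On these data alone, whether an amine or a methoxy group on the same aromatic carbon would give a lower number remains open. So does whether another five-membered aromatic ring would behave like 1,3-thiazol-2-yl.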